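Two Methoxy Groups Added to a Weakly Cytotoxic Compound

The source may report more compounds than this note shows. Statements on the series, on what has been measured and on what is new or still open speak of the compounds shown alone.

Compound 1, with the structure `CC(=O)n1cc(/C=C(/C(=O)O)c2ccccc2)c2cc(OCc3ccccc3)ccc21`, was tested in a functional assay on LNCaP cells (Homo sapiens) for cytotoxicity, read by MTT assay, with a stated time of 72 h; a lower number here means a stronger inhibitor, a higher number a weaker inhibitor. In that test compound 1 gives > 100000 nM, which is a limit of the assay rather than a measured number. Compound 1 thus stands at the limit of > 100000 nM in this assay, at which 1 of the 3 values shown sits. A related compound 2, `COc1ccc(/C(=C\c2c[nH]c3ccc(OCc4ccccc4)cc23)C(=O)O)cc1`, gives "not determined" (no result reported) in this assay. Compound 3, `COc1ccc(Cn2cc(/C=C(/C(=O)O)c3ccccc3)c3cc(OCc4ccccc4)ccc32)cc1`, gives 38200 nM in this assay, and the step of an at least 2.6-fold lower number from compound 1 to compound 3 (0.41 log units; beyond the scatter) shows that exchanging the group on the aromatic nitrogen brings the number into the measurable range.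

Compound 4, `COc1cc(OC)cc(/C(=C\c2cn(C(C)=O)c3ccc(OCc4ccccc4)cc23)C(=O)O)c1`, differs from compound 1 in a different place: 3,5-dimethoxyphenyl in place of phenyl on a double-bonded chain carbon bound to a carbonyl carbon and a double-bonded chain carbon. The acetyl on the aromatic nitrogen is kept. Among the measured compounds shown here, no measured step touches this part of the molecule; the one measured step concerns the nitrogen substituent only, so it offers no guide for the ring at this position. With nothing measured for this change, compound 4 is expected to stay weak, and a step of an at least 1.1-fold lower number from compound 1 to compound 4 (0.04 log units; that floor lies within the scatter) is estimated, meaning no change beyond the scatter. Compound 4 is therefore estimated at 90000 nM, within a range from 20000 nM to 400000 nM, with a real chance that only a limit is reported once more.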

Compound 4, half-maximal inhibitory concentration: 26100 nM
Beside the measured number, compound 4's estimate is 3.4-fold (0.54 log units) above it; measured number inside the range.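

In this assay the ring on a double-bonded chain carbon bound to a carbonyl carbon and a double-bonded chain carbon proves to be a place where a change registers: 3,5-dimethoxyphenyl in place of phenyl brings an at least 3.8-fold lower number from compound 1 to compound 4 (0.58 log units; beyond the scatter) with the acetyl on the aromatic nitrogen left as it was. Until now only the group on that nitrogen had been seen to move the number, so this second site shows that the core of compound 1 can be brought into the measurable range from more than one part of the molecule, though the number stays high in plain terms. The true size of the step cannot be stated, only its floor, because the starting point is a limit of the assay and not a number: the limit of > 100000 nM in this assay, at which 1 of the 4 values shown sits.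

On these data alone, whether both methoxy groups are needed remains open, as does whether a hydroxyl, an amine or a fluorine on this ring would give a similar number. Also open, as far as these compounds go, are what 3,5-dimethoxyphenyl does when joined with 4-methoxybenzyl on the aromatic nitrogen, and what a methyl ester would do in place of the carboxylic acid.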